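The source may hold more compounds than are shown below. What is called first, only, known or untested is meant among the compounds shown, and "the series" means these compounds.

Among the compounds with values here, compound 2 `Cc1ccc(-n2nc(C(=O)Nc3ccc(Oc4ncnc5[nH]ccc45)c(F)c3)c(C)cc2=O)cc1` gives 18500 nM in a functional assay on A549 cells (Homo sapiens) for cytotoxicity, read by MTT assay, with a stated time of 72 h (on this read-out higher numbers stand for weaker inhibition and lower numbers for stronger inhibition), the lowest of the two numbers measured so far. Compound 1 `Cc1cc(=O)n(-c2ccc(F)cc2)nc1C(=O)Nc1ccc(Oc2ncnc3[nH]ccc23)c(F)c1` gives 42400 nM, and the step of a 2.3-fold lower number from compound 1 to compound 2 (0.36 log units; beyond the scatter) is a modest one beyond the usual scatter. Compound 3 `Cc1cc(=O)n(-c2ccccc2OC(F)(F)F)nc1C(=O)Nc1ccc(Oc2ncnc3[nH]ccc23)c(F)c1` carries 2-(trifluoromethoxy)phenyl in place of 4-methylphenyl on an aromatic nitrogen. Within the data shown here, the only measured step, from compound 1 to compound 2, also altered this phenyl ring, but only by a single small group, so it gives weak guidance for a larger and differently placed group. A step no larger than the scatter, or a small rise, is expected, a 1.6-fold higher number from compound 2 to compound 3 (0.21 log units; within the scatter). Compound 3 is estimated at 30000 nM, within 8000 nM to 120000 nM.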

Compound 3, half-maximal inhibitory concentration: 16200 nM
Beside the measured number, compound 3's estimate is 1.9-fold (0.27 log units) above it, and the stated range covers the measured number.
By their numbers in this assay, from the lowest: compounds 3 and 2 (each within the scatter of the next); then compound 1.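

Replacing 4-methylphenyl with 2-(trifluoromethoxy)phenyl on the aromatic nitrogen gives a 1.1-fold lower number from compound 2 to compound 3 (0.06 log units; within the scatter), so the read-out holds steady even though the entering group has more heavy atoms and a different substitution pattern. Replacing the 4-fluorophenyl of compound 1 with the same group gives a 2.6-fold lower number from compound 1 to compound 3 (0.42 log units; beyond the scatter), which leaves compound 1 apart from compound 2 and compound 3. No supporting data explain these numbers.

The compounds shown never place one group at two ring positions, so the effects of group and placement remain unseparated. On these data alone, whether a phenyl ring bearing an amine or a carboxylic acid would shift the numbers also remains open.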